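Fluoro in place of methoxy on the shared core

The source may hold more compounds than are shown below. What is called first, only, known or untested is meant among the compounds shown, and "the series" means these compounds.

In a functional assay on Molt4/C8 cells (Homo sapiens) for inhibition (a higher number here means a weaker inhibitor, a lower number a stronger inhibitor), compound 1 `O=C1/C(=C/c2ccccc2Cl)CCCc2ccccc21` gives 37100 nM, and compound 2 `COc1ccccc1/C=C1\CCCc2ccccc2C1=O` gives 37100 nM. Going by the values given here, compound 2 therefore stands level with compound 1, its only measured neighbour. Among the compounds with values here, the one measured step shows no change at the digits printed from compound 1 to compound 2 (within the scatter), for methoxy in place of chloro on an aromatic carbon. Compound 3 `O=C1/C(=C/c2ccccc2F)CCCc2ccccc21` carries fluoro in place of methoxy on an aromatic carbon, ortho to a large group: fluoro in place of methoxy on an aromatic carbon. Within the data shown here, no fluoro compound has been measured yet, and a single step is thin support, so the expectation stays broad. Resting on the step from chloro to methoxy between compound 1 and compound 2, with compound 2 at 37100 nM, no change beyond the scatter is expected. The expected step is a 1.0-fold lower number from compound 2 to compound 3 (0.01 log units; within the scatter). Compound 3 is estimated at 36000 nM, with an expected range of 15000 nM to 80000 nM.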

Compound 3, half-maximal inhibitory concentration: 42100 nM
Compound 3: the middle estimate sits 1.2-fold (0.07 log units) below what was measured; the range from low to high includes it.
By their numbers in this assay, from the lowest: compounds 1, 2 and 3 (each within the scatter of the next).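

In this assay, on an aromatic carbon ortho to a large group, the data give a 1.1-fold higher number from compound 2 to compound 3 (0.05 log units; within the scatter) for fluoro in place of methoxy and a 1.1-fold higher number from compound 1 to compound 3 (0.05 log units; within the scatter) for fluoro in place of chloro at the same place on the shared core. Fluoro, with 1 heavy atom against 2 for methoxy, therefore joins chloro and methoxy in a set of three that this read-out does not separate, where earlier only a single pair stood level. No measurement is available that bears on why these values stay together.

Still open, from the compounds shown here alone, is whether an amine, a carboxylic acid or a longer chain such as butoxy at this place would move the number beyond the scatter. Also open, going by these compounds, is whether chloro, methoxy and fluoro would stay level at another place on that aromatic ring.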